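This account rests on a few compounds, and the source may have more. Where it says the series, first, only, none or still open, it means among the compounds named here.

Working notes on the series. In a functional assay on MCF7 cells (Homo sapiens) for antiproliferative activity, read by sulforhodamine B assay, with a stated time of 72 h (on this read-out lower numbers stand for stronger inhibition and higher numbers for weaker inhibition), compound 1 `COc1ncc(-c2ccc3ncnc(Nc4cnn(CCC(=O)O)c4)c3c2)cc1NS(C)(=O)=O` gives 560 nM. Compound 2 `COc1ncc(-c2ccc3ncnc(Nc4cnn(CC(=O)O)c4)c3c2)cc1NS(=O)(=O)c1ccc(F)cc1F` gives 700 nM in this assay, which is the highest of the two numbers recorded so far; the gap to compound 1 lies within the scatter, so the two values are read as equivalent. Compound 3 `COc1cc(Nc2ncnc3ccc(-c4cnc(OC)c(NS(=O)(=O)c5ccc(F)cc5F)c4)cc23)ccc1OCCO` differs from compound 2 in one place: 4-(2-hydroxyethoxy)-3-methoxyphenyl in place of 1-(carboxymethyl)-1H-pyrazol-4-yl on a nitrogen on an aromatic ring. Among the measured compounds shown here, no measured pair in this set tracks this kind of exchange, so nothing in the numbers argues for a step in either direction. The expected step from compound 2 to compound 3 in this assay is therefore a 1.4-fold lower number from compound 2 to compound 3 (0.15 log units; within the scatter), treated as no movement beyond the scatter. Compound 3 is accordingly estimated at 500 nM, with a range from 120 nM to 2500 nM to reflect the lack of a comparable step among the measured compounds.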

Compound 3, half-maximal inhibitory concentration: 2260 nM
Beside the measured number, compound 3's estimate is 4.5-fold (0.66 log units) below it; low and high end bracket the measured number.
By their numbers in this assay, from the lowest: compounds 1 and 2 (each within the scatter of the next); then compound 3.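

In this assay, the substituent on a nitrogen on an aromatic ring proves able to move the number: 4-(2-hydroxyethoxy)-3-methoxyphenyl in place of 1-(carboxymethyl)-1H-pyrazol-4-yl gives a 3.2-fold higher number from compound 2 to compound 3 (0.51 log units; beyond the scatter), a modest step. The two groups have the same counts of hydrogen-bond donors and acceptors and neither carries a net charge, so these counts do not account for the difference between compound 2 and compound 3. No supporting measurement bears on the origin of this step.

The exchange changes the ring, the carboxylic acid and the chain together, so the shown compounds leave open which of these parts accounts for the step. A 1-(2-hydroxyethyl)-1H-pyrazol-4-yl group, or a phenyl ring carrying a carboxymethyl group, at this position would separate these parts.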